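This account rests on a few compounds, and the source may have more. Where it says the series, first, only, none or still open, it means among the compounds named here.

Measured compounds in an ADME assay on HEL cells (Homo sapiens) for cytotoxicity, with a stated time of 3 days; on this read-out lower numbers stand for higher toxicity in this test and higher numbers for lower toxicity in this test:
compound 1, `CCC1(Cc2ccccc2)OS(=O)(=O)C=C1OCC(=O)OC`: > 400000 nM, a limit of the assay
compound 2, `CC1(C(c2ccccc2)c2ccccc2)OS(=O)(=O)C=C1OCc1ccccc1`: >= 400000 nM, a limit of the assay
compound 3, `CCC1(Cc2ccccc2)OS(=O)(=O)C=C1OC(c1ccccc1)c1ccccc1`: >= 80000 nM, a limit of the assay

None of the three compounds gives a number in this assay. Compound 1 sits at the limit of > 400000 nM in this assay, at which 1 of the 3 values shown sits. Compound 2 sits at the limit of >= 400000 nM in this assay, at which 1 of the 3 values shown sits. Compound 3 sits at the limit of >= 80000 nM in this assay, at which 1 of the 3 values shown sits. So compound 1 stands at the highest of the three limits, and nothing in these values separates any of the three compounds from the others.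

Compound 4, `CCC1(Cc2ccccc2)OS(=O)(=O)C=C1OCc1ccc(Cl)cc1`, has not yet been measured. It differs from compound 1 in one place: 4-chlorophenyl in place of methoxycarbonyl on a saturated chain carbon bound to an oxygen on an unsaturated carbon. For the measured compounds named here, since no pair of the measured compounds differs in a single place, no measured step is available to size this change against. With compound 2 and compound 3, which carry aromatic ether groups on the shared core, both also reaching only limits, no direction beyond the scatter is expected for compound 4.

Compound 4 is therefore expected to show a number no higher from compound 1 to compound 4 (the limit leaves the size open), that is, an estimated value of 400000 nM, with a range from 100000 nM to 1000000 nM, most likely again as a limit rather than a number.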

Compound 4, minimum cytotoxic concentration: >= 50000 nM
Compound 4 ended at the assay's limit; the forecaster's own chance of this, stated with the estimate: 80%; the middle value does not contradict the limit.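

In this assay compound 4 gives >= 50000 nM, a limit of the assay. Compound 1 gives > 400000 nM, also a limit, so the step between these two compounds cannot be read. The compounds shown leave open at what concentration any of them turns cytotoxic, and whether 4-chlorophenyl in place of methoxycarbonyl changes that concentration at all.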